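Dropping the phenyl spacer before the ester

The source may hold more compounds than are shown below. What is called first, only, known or untested is meant among the compounds shown, and "the series" means these compounds.

Measured so far:
- compound 1 `CCCCCCCCc1ccc(OCC(=O)Cn2nnc(C)n2)cc1` — in an ADME assay on S9 fraction from liver (Rattus norvegicus) for metabolic stability, read by LC-MS, using NADPH, with a stated time of 30 min (on this read-out higher numbers stand for a more stable compound and lower numbers for a less stable compound), compound 1 gives < 5%, which is a limit of the assay rather than a number.
- compound 2 `CCCCCCCCc1ccc(OCC(=O)Cn2nnc(-c3cccc(C(=O)OC)c3)n2)cc1` — in this assay compound 2 gives 19%.
- compound 3 `CCCCCCCCc1ccc(OCC(=O)Cn2nnc(-c3cccc(S(=O)(=O)N(C)C)c3)n2)cc1` — in this assay compound 3 gives 9%.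

Compound 2 stands at the higher of the two numbers shown, but compound 3 sits a number 10 percentage points lower from compound 2 to compound 3 (within the scatter), so the two cannot be ranked against each other. The third value is only a limit (the limit of < 5% in this assay, at which 1 of the 3 values shown sits).

Compound 4 `CCCCCCCCc1ccc(OCC(=O)Cn2nnc(C(=O)OC)n2)cc1` differs from compound 2 in one place: methoxycarbonyl in place of 3-(methoxycarbonyl)phenyl on an aromatic carbon. The ester stays, but the six-membered ring that carried it is gone, so the ester now sits directly on the five-membered aromatic ring with 4 nitrogen.

For the measured compounds named here, two measured steps bear on this. Adding 3-(methoxycarbonyl)phenyl in place of methyl gave a number at least 14 percentage points higher from compound 1 to compound 2 (beyond the scatter), the only clear gain in the set. Exchanging the group on that phenyl gave a number 10 percentage points lower from compound 2 to compound 3 (within the scatter). Compound 4 keeps less of what separated compound 2 from compound 1, so a drop in this assay toward the lower end is expected, roughly a number 11 percentage points lower from compound 2 to compound 4 (beyond the scatter). The estimate for compound 4 is 8%, with a range from 2% to 18%. A value reported only as a limit is a real possibility for compound 4.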

Compound 4, percent of the compound remaining: < 5%
Compound 4: a limit, no number; the forecaster's own chance of this, stated with the estimate: 30%; middle value at least 3 percentage points away from the limit.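

In this assay, taking away the six-membered aromatic ring of carbon only while keeping the ester gives a number at least 14 percentage points lower from compound 2 to compound 4 (beyond the scatter). This pair shows that methoxycarbonyl alone, on the aromatic carbon of the five-membered ring with 4 nitrogen, does not hold the number of compound 2: the ester and the ring that carried it have to be read together here. The comparison with the other ring-bearing compound is weaker, at a number at least 4 percentage points lower from compound 3 to compound 4 (that floor lies within the scatter), so it adds little on its own. Compound 4 gives < 5%, which is a limit of the assay and not a number, so its step with compound 1 cannot be read: the limit of < 5% in this assay, at which 2 of the 4 values shown sit.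

On these data alone, what remains open is how much of the gain in compound 2 belongs to the six-membered ring itself and how much to the ester it carries, which a plain phenyl group on the same aromatic carbon would help to separate. As far as these compounds go, it is also open whether a carboxylic acid or an amide in place of the ester, on that ring or directly on the aromatic carbon, would read clear of the limit.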